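A few compounds are considered here, and "the series" means these few. Any claim that something is new, unique, unknown or untested is made for them only; others in the source may bear on it.

Measured in an ADME assay on CCRF-HSB-2 cells (Homo sapiens) for cytotoxicity, with a stated time of 7 days; on this read-out lower numbers stand for higher toxicity in this test and higher numbers for lower toxicity in this test:
- compound 1 `CCCCCCCCOc1nc(N)nc2c1ncn2/C=C1/CC1(CO)CO`: > 20000 nM
- compound 2 `Nc1nc(N2CCCC2)c2ncn(/C=C3/CC3(CO)CO)c2n1`: > 20000 nM
- compound 3 `Nc1nc(NC2CCCC2)c2ncn(/C=C3/CC3(CO)CO)c2n1`: > 20000 nM

Each of these entries is a limit of the assay and not a number.

Compound 3 stands at > 20000 nM, which is likewise only a limit. Compound 1 and compound 2 also give no number, so compound 3 cannot be ranked against either. The next compound, compound 4 `Nc1nc(NC2CCCCC2)c2ncn(/C=C3/CC3(CO)CO)c2n1`, differs from compound 3 in one group: cyclohexyl in place of cyclopentyl on a nitrogen on an aromatic ring. In words, it carries cyclohexyl in place of cyclopentyl on a nitrogen on an aromatic ring.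

Among the measured compounds shown here, two measured steps bear on this change, since both end at compound 3. They are a step that the two limits leave unreadable from compound 1 to compound 3 and a step that the two limits leave unreadable from compound 2 to compound 3. A third, a step that the two limits leave unreadable from compound 1 to compound 2, changes the same group. None of them has a readable size, and the whole series shows (the limit of > 20000 nM in this assay, at which 3 of the 3 values shown sit). The data therefore offer no measured effect of changing this group in this assay. With no sign of a shift in either direction, no step beyond the scatter is expected, and compound 4 will most likely also report only a limit.

For compound 4 the estimated value is 20000 nM, with an expected range of 10000 nM to 40000 nM. This estimate amounts to an expected a number no higher from compound 3 to compound 4 (the limit leaves the size open).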

Compound 4, half-maximal cytotoxic concentration: > 20000 nM
Compound 4 gave a limit, no number (the forecaster's own chance of this, stated with the estimate: 85%); the middle value lies on the limit itself.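

In this assay compound 4 gives > 20000 nM, which is a limit and not a number. No new step can be read from compound 1, compound 2 or compound 3 to compound 4, and the whole series shows one limit: the limit of > 20000 nM in this assay, at which 4 of the 4 values shown sit.

The compounds shown leave open whether any of these groups on the shared core changes the half-maximal cytotoxic concentration.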